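A new group on the carbonyl of compound 3

The source may report more compounds than this note shows. Statements on the series, on what has been measured and on what is new or still open speak of the compounds shown alone.

compound 1 `CCn1c(C(=O)NCCN(C)C)ccc1C(CC)(CC)c1ccc(OCCC(O)(CC)CC)c(C)c1`: 990 nM
compound 2 `CCN(CC)CCNC(=O)c1ccc(C(CC)(CC)c2ccc(OCCC(O)(CC)CC)c(C)c2)n1CC`: 2290 nM
compound 3 `C=CCN(C)C(=O)c1ccc(C(CC)(CC)c2ccc(OCCC(O)(CC)CC)c(C)c2)n1CC`: 1190 nM

All three values come from an ADME assay on L02 cells (Homo sapiens) for antiproliferative activity, read by MTT assay, with a stated time of 48 h; on this read-out lower numbers stand for stronger inhibition and higher numbers for weaker inhibition. The compounds share one core and differ only in the group on the carbonyl carbon. Compound 3 lies within the scatter of both other compounds, as a 1.2-fold higher number from compound 1 to compound 3 (0.08 log units; within the scatter) and a 1.9-fold lower number from compound 2 to compound 3 (0.28 log units; within the scatter) show.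

The unmeasured compound 4 `CCn1c(C(=O)Nc2ccc(OC(F)(F)F)cc2)ccc1C(CC)(CC)c1ccc(OCCC(O)(CC)CC)c(C)c1` keeps the shared core but changes that group: (4-(trifluoromethoxy)phenyl)amino in place of allyl(methyl)amino on a carbonyl carbon. In words, this is (4-(trifluoromethoxy)phenyl)amino in place of allyl(methyl)amino on a carbonyl carbon.

The three measured steps give some guidance. The only one beyond the scatter, a 2.3-fold higher number from compound 1 to compound 2 (0.36 log units; beyond the scatter), is modest and exchanges dimethylamino for diethylamino. The two steps above, which replace the whole group on the carbonyl carbon, are no larger. None of the three brings in an aromatic ring, so they guide this change only loosely. A step of similar modest size is therefore expected in this assay, leaning weakly towards a higher number, though it may stay within the scatter. The expected change is a 1.5-fold higher number from compound 3 to compound 4 (0.18 log units; within the scatter). For compound 4 the estimated value is 1800 nM, with an expected range of 600 nM to 6000 nM.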

Compound 4, half-maximal inhibitory concentration: > 50000 nM
Compound 4: only a limit was reported; the forecaster's own chance of this, stated with the estimate: 10%; middle value at least 27-fold (1.44 log units) from the limit.
By their numbers in this assay, from the lowest: compounds 1, 3 and 2 (each within the scatter of the next, the first and the last beyond it). At a limit, above all of these: compound 4.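

In this assay, compound 4 gives a limit rather than a number: the limit of > 50000 nM in this assay, at which 1 of the 4 values shown sits. Read against that limit, the change at this position is an at least 42-fold higher number from compound 3 to compound 4 (1.62 log units; beyond the scatter), alongside an at least 21-fold higher number from compound 2 to compound 4 (1.33 log units; beyond the scatter) and an at least 50-fold higher number from compound 1 to compound 4 (1.70 log units; beyond the scatter). The earlier compounds shown here showed only small shifts among groups without a ring on the carbonyl carbon, whereas this result shows that the group there can matter far more than they suggested, and the amide hydrogen alone does not separate the compounds, since compound 1 and compound 2 carry one as well.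

Compound 4 alters several things at once, bringing in an aromatic ring and a trifluoromethoxy group together, so the compounds shown cannot say which of these goes with the loss; plain phenylamino, with no trifluoromethoxy group, or benzylamino, with one more carbon before the ring, would help to separate them. Going by these compounds, the true size of all three new steps also remains open, as each rests on a limit and not on a number.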